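This account rests on a few compounds, and the source may have more. Where it says the series, first, only, none or still open, it means among the compounds named here.

Working notes on the series. In a functional assay on HepG2 cells (Homo sapiens) for inhibition, read by MTT assay, with a stated time of 72 h (a lower number here means a stronger inhibitor, a higher number a weaker inhibitor), compound 1 `Cc1ccc(CN2CCc3ncn(COCc4ccccc4)c3/C(=C/c3ccccc3)C2=O)cc1` gives 44700 nM, compound 2 `Cc1cc(C)cc(CN2CCc3ncn(COCc4ccccc4)c3/C(=C/c3ccccc3)C2=O)c1` gives 40900 nM, and compound 3 `O=C1/C(=C\c2ccccc2)c2c(ncn2COCc2ccccc2)CCN1Cc1ccc(Cl)cc1` gives 47900 nM. Compound 2 therefore sits with the other two compounds, within the scatter of both, and holds no separate rank.

Compound 4 `Cc1ccccc1CN1CCc2ncn(COCc3ccccc3)c2/C(=C/c2ccccc2)C1=O` is still to be measured. It carries 2-methylphenyl in place of 3,5-dimethylphenyl on a saturated chain carbon bound to an amide-type nitrogen in a ring.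

Within the data shown here, three measured steps bear on this change. The first is a 1.1-fold lower number from compound 1 to compound 2 (0.04 log units; within the scatter), which exchanges 4-methylphenyl for 3,5-dimethylphenyl at the same place. The second is a 1.2-fold higher number from compound 2 to compound 3 (0.07 log units; within the scatter), which brings in 4-chlorophenyl there. The third is a 1.1-fold higher number from compound 1 to compound 3 (0.03 log units; within the scatter), which exchanges methyl for chloro on an aromatic carbon. All three are small and within the scatter. Among the measured compounds shown here, no measured compound carries 2-methylphenyl, so this substitution remains untested and the range is kept wide.

No step beyond the scatter is expected in this assay, and neither direction is favoured. The expected change is a 1.1-fold higher number from compound 2 to compound 4 (0.03 log units; within the scatter). Compound 4 is estimated at 44000 nM, with an expected range of 25000 nM to 78000 nM.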

Compound 4, half-maximal inhibitory concentration: 53300 nM
For compound 4 the middle estimate is 1.2-fold (0.08 log units) below the measured one; the measured number falls inside the stated range.
By their numbers in this assay, from the lowest: compounds 2, 1, 3 and 4 (each within the scatter of the next).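

In this assay, 2-methylphenyl on a saturated chain carbon bound to an amide-type nitrogen in a ring gives a 1.3-fold higher number from compound 2 to compound 4 (0.12 log units; within the scatter) and a 1.2-fold higher number from compound 1 to compound 4 (0.08 log units; within the scatter) and also a 1.1-fold higher number from compound 3 to compound 4 (0.05 log units; within the scatter) at this place. The earlier compounds shown here covered only 4-methylphenyl, 3,5-dimethylphenyl and 4-chlorophenyl; with 2-methylphenyl added, all four compounds stay within the scatter of one another, so none of the four aryl groups separates from the rest and the numbers give no order among them. No measurement at hand accounts for how close these numbers lie.

Going by these compounds, all four compounds carry a single phenyl ring with only methyl or chloro on it at this place, so it remains open whether a carboxylic acid or a dimethylamino group on that ring, or a longer chain in place of the benzyl link, would move the number beyond the scatter. They also share the rest of the core of compound 1, which leaves the response to any change outside this place unknown.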